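Trimming the amide side chain of compound 3

This account rests on a few compounds, and the source may have more. Where it says the series, first, only, none or still open, it means among the compounds named here.

Compound 3 `CCCn1cc(Cc2ccc(C(=O)NS(=O)(=O)c3ccccc3C)cc2OC)c2cc(C(=O)NCC(CC)CC)ccc21` gives 8.9 in an assay on isolated protein for binding affinity to cysteinyl leukotriene receptor 1 (Cavia porcellus) (a higher number here means a more potent compound, by a factor of ten per unit of this negative logarithm, a lower number a less potent compound), the second highest of the three values here; compound 1 `COc1cc(C(=O)NS(=O)(=O)c2ccccc2C)ccc1Cc1cn(C)c2ccc(C(=O)NCC(C)C)cc12` gives 8.6, within the scatter of compound 3, while compound 2 `CCC(CC)CNC(=O)c1ccc2c(c1)c(Cc1ccc(C(=O)NS(=O)(=O)c3ccccc3C)cc1OC)cn2CC` gives 9.5, the highest. Within the data shown here, the only counted step, a number 0.60 log units lower from compound 2 to compound 3 (beyond the scatter), touches a different place from the change to compound 4 `CCCn1cc(Cc2ccc(C(=O)NS(=O)(=O)c3ccccc3C)cc2OC)c2cc(C(=O)NCC(C)C)ccc21`, which is isopropyl in place of pentan-3-yl on a saturated chain carbon bound to an amide-type nitrogen. Among the measured compounds shown here, no measured pair isolates this change; compound 1 carries the isobutyl amide and a methyl on the aromatic nitrogen, yet its value and that of compound 3 lie within the scatter. Compound 4 is therefore expected to stay close to compound 3, with a step of a number 0.20 log units lower from compound 3 to compound 4 (within the scatter), and its estimate in this assay is 8.7, in the range 8.1 to 9.3.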

Compound 4, negative logarithm of the antagonist equilibrium constant: 9.1
Compound 4: the middle estimate sits 0.40 log units below what was measured; measured number inside the range.
By their numbers in this assay, from the lowest: compounds 1, 3 and 4 (each within the scatter of the next, the first and the last beyond it); then compound 2.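

In this assay, isopropyl in place of pentan-3-yl on the saturated chain carbon bound to the amide-type nitrogen gives a number 0.20 log units higher from compound 3 to compound 4 (within the scatter), so this pair shows the smaller group holding the value of the larger one. The isobutyl amide also allows a one-place reading of the chain on the aromatic nitrogen, which gives a number 0.50 log units higher from compound 1 to compound 4 (beyond the scatter). Nothing available explains either step. The compounds shown leave open how a cyclohexyl group or an amine would read on the amide side chain.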